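The compounds below may be only part of what the source reports. "The series", "measured", "known", "first", "only" and "open" are said of these compounds alone.

Among the compounds with values here, compound 2 `CNC(=O)N1CCCc2ccc(NC(=O)c3ccc(-c4cnn(C(C)=O)c4)cc3)cc21` gives 23.9% in a functional assay on MV4-11 cells (Homo sapiens) for antiproliferative activity, with a stated time of 6 days, tested at 1.56 uM (a higher number here means a stronger effect of the compound at the concentration tested, a lower number a weaker effect), and is the lowest of the two numbers measured so far. Within the data shown here, its nearest neighbour is compound 1 `CNC(=O)N1CCCc2ccc(NC(=O)c3ccc(-c4ccncc4)cc3)cc21`, which in this assay gives 37.6%; the single measured step, a number 13.7 percentage points lower from compound 1 to compound 2 (beyond the scatter), was a modest drop beyond the scatter on putting 1-acetyl-1H-pyrazol-4-yl in place of pyridin-4-yl. Compound 3 `CNC(=O)N1CCCc2ccc(NC(=O)c3ccc(-c4cc[nH]n4)cc3)cc21` has not yet been measured. Its change from compound 2 is 1H-pyrazol-3-yl in place of 1-acetyl-1H-pyrazol-4-yl on an aromatic carbon. Among the measured compounds shown here, no measured step removes the acetyl from this pyrazole while moving its point of attachment, so the step to compound 3 has no direct precedent; the only reference is the gap between compound 1 and compound 2. On that basis compound 3 is expected to land between the two measured numbers, a change of about a number 6.1 percentage points higher from compound 2 to compound 3 (within the scatter) in this assay that may not exceed the scatter. The estimate for compound 3 is 30%, in the range 10% to 50%.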

Compound 3, a percentage reported as inhibition, at one concentration (the size of the read-out at that concentration, not a potency): 92.5%
The estimate for compound 3 lay 62.5 percentage points below the measured number, outside the stated range (above it).
By their numbers in this assay, from the lowest: compound 2; then compound 1; then compound 3.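

In this assay, the aromatic carbon para to a large group proves far more responsive than the first pair suggested: 1H-pyrazol-3-yl in place of 1-acetyl-1H-pyrazol-4-yl gives a number 68.6 percentage points higher from compound 2 to compound 3 (beyond the scatter), and the same group in place of pyridin-4-yl gives a number 54.9 percentage points higher from compound 1 to compound 3 (beyond the scatter). The first of these steps combines three changes, since it loses the acetyl, shifts the point of attachment on the pyrazole and goes from 0 hydrogen-bond donors to 1. Nothing available explains why the read-out rises so sharply.

Which of these changes carries the rise remains open, and the unacetylated 1H-pyrazol-4-yl group would help to separate them. Also open, from the compounds shown here alone, is whether the read-out would hold with a methyl group on the pyrazole nitrogen or an amine on the pyrazole ring.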